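Chloro for Fluoro on a Fused Aryl Sulfonamide Core

This account rests on a few compounds, and the source may have more. Where it says the series, first, only, none or still open, it means among the compounds named here.

Compound 1, `CC(C)S(=O)(=O)Nc1cccc2c1CCCC2c1c[nH]cn1`, in an assay on isolated protein (Cricetulus griseus) for binding affinity to Alpha-1B adrenergic receptor (Mesocricetus auratus), read by radioligand binding (on this read-out lower numbers stand for stronger inhibition and higher numbers for weaker inhibition), compound 1 gives < 10000 nM, a limit of the assay.
Compound 2, `COc1ccc2c(c1NS(C)(=O)=O)CCCC2c1c[nH]cn1`, in this assay compound 2 gives 1700 nM.
Compound 3, `CCS(=O)(=O)Nc1cc(F)cc2c1CCCC2c1c[nH]cn1`, in this assay compound 3 gives < 10000 nM, a limit of the assay.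

Compound 3 thus stands only on a limit, not on a number, and it shares that limit with one other compound: the limit of < 10000 nM in this assay, at which 2 of the 3 values shown sit. Compound 4, `CCS(=O)(=O)Nc1cc(Cl)cc2c1CCCC2c1c[nH]cn1`, differs from compound 3 by chloro in place of fluoro on an aromatic carbon. Going by the values given here, no measured pair shows this change, so no direction beyond the scatter is expected from compound 3 to compound 4; the step is estimated as a step that the limit leaves unreadable from compound 3 to compound 4. Compound 4 is expected near 3000 nM, within 800 nM to 12000 nM.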

Compound 4, inhibition constant: < 10000 nM
Compound 4 gave a limit, no number; the forecaster's own chance of this, stated with the estimate: 40%; the middle value does not contradict the limit.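

Compound 3 and compound 4 both rest on a limit of the assay, so no step can be read between them: the limit of < 10000 nM in this assay, at which 3 of the 4 values shown sit.

The compounds shown leave open how chloro and fluoro at this place compare in this assay.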